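The source may hold more compounds than are shown below. What is called first, only, known or untested is meant among the compounds shown, and "the series" means these compounds.

In an ADME assay, at pH 5 (on this read-out higher numbers stand for a longer-lived compound and lower numbers for a shorter-lived compound), compound 2 (`COc1cnc(C[S+]([O-])c2nc3cc(OC(F)(F)C(F)F)ccc3[nH]2)cc1OC`) gives 2.9 h. Compound 1 (`COc1cnc(C[S+]([O-])c2nc3cc(OC(F)F)ccc3[nH]2)cc1OC`) gives 2.1 h, within the scatter of compound 2, while compound 3 (`COc1cnc(C[S+]([O-])c2nc3cc(OC(F)(F)C(F)F)ccc3[nH]2)c(C)c1OC`) gives 6.8 h, beyond the scatter of compound 2. Compound 4 (`COc1cc(C[S+]([O-])c2nc3cc(OC(F)(F)C(F)F)ccc3[nH]2)ncc1C`) is not yet measured. It departs from compound 2 by a single change: methyl in place of methoxy on an aromatic carbon.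

Within the data shown here, two measured steps bear on this, and neither is the same change. The closer one is a 2.3-fold higher number from compound 2 to compound 3 (0.37 log units; beyond the scatter): a modest step beyond the scatter, in which a methyl also arrives on an aromatic carbon, but in place of hydrogen, with no methoxy leaving. The other, a 1.4-fold higher number from compound 1 to compound 2 (0.14 log units; within the scatter), lies within the scatter and concerns the fluorinated chain, a different part of the molecule. Among the measured compounds shown here, no measured step removes a methoxy, so the data fix no direction for this change. In this assay, no step beyond the scatter is therefore expected, and the range is kept wide on both sides. The estimated move is a 1.3-fold lower number from compound 2 to compound 4 (0.12 log units; within the scatter). For compound 4 the expected half-life is 2.2 h, with an estimated range of 1.1 h to 4.5 h.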

Compound 4, half-life: 0.2 h
The estimate for compound 4 lay 11-fold (1.04 log units) above the measured number, outside the stated range (below it).
By their numbers in this assay, from the lowest: compound 4; then compounds 1 and 2 (each within the scatter of the next); then compound 3.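

Swapping methoxy for methyl on this aromatic carbon, two atoms from the ring nitrogen and para to a large group, gives a 15-fold lower number from compound 2 to compound 4 (1.16 log units; beyond the scatter) in this assay, a large step where the earlier steps on this series were modest or within the scatter. A methyl on this ring therefore carries no single direction in these data: the arrival of a methyl in place of hydrogen gave a 2.3-fold higher number from compound 2 to compound 3 (0.37 log units; beyond the scatter), while the same group arriving in place of methoxy moves the number the opposite way and much further, so the identity of the group leaving matters as much as the methyl itself. No measurement among these compounds gives a reason for this loss of half-life.

The step exchanges two things at once, so these compounds do not separate the loss of the methoxy from the arrival of the methyl, and a hydrogen, an ethoxy or an amine at this carbon would be needed to tell them apart. Also open, going by these compounds, is whether the other methoxy on this ring is as sensitive to the same exchange, and whether the step carries over to the core of compound 1 with its shorter fluorinated chain.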